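Side-chain replacements on the sulfur-linked chain of the shared core

The source may hold more compounds than are shown below. What is called first, only, known or untested is meant among the compounds shown, and "the series" means these compounds.

Measured so far in a functional assay on HT cells (Homo sapiens) for antiproliferative activity, read by fluorescence, with a stated time of 72 h; on this read-out higher numbers stand for weaker inhibition of growth and lower numbers for stronger inhibition of growth:
compound 1 `CC(C)c1n[nH]c2c(NCc3ccc(-c4ccccn4)cc3)nc(SCC3CNC(=O)O3)nc12`, 80 nM
compound 2 `CC(C)c1n[nH]c2c(NCc3ccc(-c4ccccn4)cc3)nc(SCC(O)CN)nc12`, 55 nM
compound 3 `CC(C)c1n[nH]c2c(NCc3ccc(-c4ccccn4)cc3)nc(SCCN)nc12`, 22 nM

Compound 1 has the highest number of the three in this assay; compound 2 sits within the scatter of it, as a 1.5-fold lower number from compound 1 to compound 2 (0.16 log units; within the scatter) shows, while a 3.6-fold lower number from compound 1 to compound 3 (0.56 log units; beyond the scatter) is a modest step beyond the scatter, and a 2.5-fold lower number from compound 2 to compound 3 (0.40 log units; beyond the scatter) points the same way.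

Compound 4 `CC(C)c1n[nH]c2c(NCc3ccc(-c4ccccn4)cc3)nc(SCCNC(=N)N)nc12` is not yet measured. It differs from compound 1 by a group of 5 heavy atoms (2 carbon, 3 nitrogen; no ring) in place of a group of 6 heavy atoms (3 carbon, 1 nitrogen, 2 oxygen; one five-membered non-aromatic ring with 2 hetero atoms), on a saturated chain carbon bound to a sulfur. The chain of compound 4 is an extended form of the aminomethyl chain of compound 3, so a 3.6-fold lower number from compound 1 to compound 3 (0.56 log units; beyond the scatter) is the step that bears most on it, with a 1.5-fold lower number from compound 1 to compound 2 (0.16 log units; within the scatter) showing that a ring-free chain in itself changes little. A modest lowering of the number is therefore expected, as a 2.3-fold lower number from compound 1 to compound 4 (0.36 log units; beyond the scatter), giving an estimate for compound 4 of 35 nM, with a range from 12 nM to 100 nM.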

Compound 4, concentration for 50% growth inhibition: 390 nM
For compound 4 the middle estimate is 11-fold (1.05 log units) below the measured one; measured number above the stated range.
By their numbers in this assay, from the lowest: compound 3; then compounds 2 and 1 (each within the scatter of the next); then compound 4.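

In this assay, substitution on the amine nitrogen gives the largest step seen on this chain so far, an 18-fold higher number from compound 3 to compound 4 (1.25 log units; beyond the scatter). Compound 4 is also the only one placed above the other side chains, with a 4.9-fold higher number from compound 1 to compound 4 (0.69 log units; beyond the scatter) and a 7.1-fold higher number from compound 2 to compound 4 (0.85 log units; beyond the scatter), so being ring-free does not by itself keep the number low on this chain. Nothing available accounts for this rise.

As far as these compounds go, it remains open whether a smaller group on the amine nitrogen, such as methyl or acetyl, would raise the number as well. A longer chain ending in the same primary amine is also untested in the compounds shown.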